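Trifluorophenyl Variant of a Nucleoside Antiproliferative Series

The source may report more compounds than this note shows. Statements on the series, on what has been measured and on what is new or still open speak of the compounds shown alone.

Measured compounds in a functional assay on HOS cells (Homo sapiens) for antiproliferative activity, with a stated time of 72 h; a higher number here means a weaker inhibitor, a lower number a stronger inhibitor:
- compound 1, `OC[C@H]1O[C@@H](n2cnc3c(NCc4ccc(F)cc4)ncnc32)[C@H](O)[C@@H]1O`: 13200 nM
- compound 2, `OC[C@H]1O[C@@H](n2cnc3c(NCc4ccc(Br)cc4)ncnc32)[C@H](O)[C@@H]1O`: > 166000 nM (a limit, not a number)
- compound 3, `Cc1cccc(CNc2ncnc3c2ncn3[C@@H]2O[C@H](CO)[C@@H](O)[C@H]2O)c1`: > 166000 nM (a limit, not a number)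

Compound 1 is the only one of the three with an actual number in this assay. Compound 2 and compound 3 both sit at the limit of > 166000 nM in this assay, at which 2 of the 3 values shown sit, so each gives a limit rather than a number.

Compound 4, `OC[C@H]1O[C@@H](n2cnc3c(NCc4ccc(F)c(F)c4F)ncnc32)[C@H](O)[C@@H]1O`, differs from compound 1 by 2,3,4-trifluorophenyl in place of 4-fluorophenyl on a saturated chain carbon bound to a nitrogen on an aromatic ring. Among the compounds with values here, two measured steps bear on this change: an at least 12-fold higher number from compound 1 to compound 2 (1.09 log units; beyond the scatter) and an at least 12-fold higher number from compound 1 to compound 3 (1.09 log units; beyond the scatter). Both replacements of the 4-fluorophenyl of compound 1 weakened inhibition beyond the scatter. The new change also alters that ring, so a weakening is expected for compound 4, a 3.0-fold higher number from compound 1 to compound 4 (0.48 log units; beyond the scatter). Compound 4 is therefore estimated at 40000 nM, with a range from 8000 nM to 166000 nM, and a real chance that only a limit is reported.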

Compound 4, half-maximal inhibitory concentration: > 166000 nM
Compound 4 ended at the assay's limit; the forecaster's own chance of this, stated with the estimate: 40%; middle value at least 4.1-fold (0.61 log units) from the limit.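

Keeping fluorine on the ring is not enough to hold activity in this assay: the 2,3,4-trifluorophenyl group gives an at least 12-fold higher number from compound 1 to compound 4 (1.09 log units; beyond the scatter). Among the groups shown at this place, only the 4-fluorophenyl of compound 1 gives an actual number. Compound 2, compound 3 and compound 4 all stop at one limit, so the steps among them cannot be read: the limit of > 166000 nM in this assay, at which 3 of the 4 values shown sit.

On these data alone, whether a plain phenyl ring or a chlorophenyl ring would give a number remains open. So does how far compound 4 lies beyond the limit.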